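The source may hold more compounds than are shown below. What is called first, only, known or untested is meant among the compounds shown, and "the series" means these compounds.

In a functional assay on MC-38 cells (Mus musculus) for antiproliferative activity, read by colorimetric assay and MTT assay (on this read-out higher numbers stand for weaker inhibition and lower numbers for stronger inhibition), compound 2 (`O=S(=O)(Nc1cccc2cc[nH]c12)c1ccc(Cl)cc1`) gives 7 ug/mL, within the scatter of compound 3 (`O=S(=O)(Nc1cc(Cl)cc2cc[nH]c12)c1ccc(Cl)cc1`) at 8.5 ug/mL, while compound 1 (`COc1ccc(S(=O)(=O)Nc2cccc3cc(O)[nH]c23)cc1`) gives a far lower 0.22 ug/mL. Compound 4 (`O=S(=O)(Nc1cccc2cc(O)[nH]c12)c1ccc(Cl)cc1`) is compound 2 with hydroxy in place of hydrogen on an aromatic carbon, next to the ring nitrogen. Within the data shown here, the one measured step, a 1.2-fold higher number from compound 2 to compound 3 (0.08 log units; within the scatter), involves chloro, not hydroxy, and bears only weakly. Among the measured compounds shown here, compound 1 carries this hydroxy but has methoxy where compound 4 has chloro, so no measured step isolates the change. Going by compound 1 at 0.22 ug/mL, the expected move is large and towards stronger inhibition, beyond the scatter: a 10-fold lower number from compound 2 to compound 4 (1.00 log units; beyond the scatter). The estimate for compound 4 is 0.7 ug/mL, with an expected range of 0.15 ug/mL to 4 ug/mL.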

Compound 4, half-maximal inhibitory concentration: 4.5 ug/mL
Estimate against measurement, compound 4: 6.4-fold (0.81 log units) below; measured number outside the range, above it.
By their numbers in this assay, from the lowest: compound 1; then compounds 4, 2 and 3 (each within the scatter of the next).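

In this assay hydroxy in place of hydrogen on an aromatic carbon, next to the ring nitrogen, gives a 1.6-fold lower number from compound 2 to compound 4 (0.19 log units; within the scatter), so with chloro on the sulfonyl-bearing ring this change alone leaves the number within the scatter. With the hydroxy held constant, the large difference follows the other substituent: a 20-fold higher number from compound 1 to compound 4 (1.31 log units; beyond the scatter). No measured evidence explains this dependence on methoxy or chloro.

Going by these compounds, whether methoxy gives a low number without the hydroxy remains open. So does the effect of an amine or a carboxylic acid in place of the hydroxy, with methoxy retained.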